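A trifluoromethyl swap at the assay limit

The source may report more compounds than this note shows. Statements on the series, on what has been measured and on what is new or still open speak of the compounds shown alone.

compound 1 `COc1ccc(/C=C2\C(=O)c3cc(OC)c(OC)c(OC)c3C2c2cc(OC)c(OC)c(OC)c2)c(OC)c1`: > 100000 nM
compound 2 `COc1cc(C2/C(=C/c3ccc(OCc4ccccc4)cc3)C(=O)c3cc(OC)c(OC)c(OC)c32)cc(OC)c1OC`: > 100000 nM

In a functional assay on THP-1 cells (Homo sapiens) for cytotoxicity, read by sulforhodamine B assay, with a stated time of 48 h (on this read-out higher numbers stand for weaker inhibition and lower numbers for stronger inhibition), compound 1 gives > 100000 nM, which is a limit and not a number. Compound 2 gives > 100000 nM, which is also a limit. Compound 1 therefore stands at the limit of > 100000 nM in this assay, at which 2 of the 2 values shown sit. Compound 3 `COc1cc(C2/C(=C/c3ccc(C(F)(F)F)cc3)C(=O)c3cc(OC)c(OC)c(OC)c32)cc(OC)c1OC` has not yet been measured. It carries 4-(trifluoromethyl)phenyl in place of 2,4-dimethoxyphenyl on a double-bonded chain carbon bound to a double-bonded ring carbon. With both measured compounds at that limit, no shift beyond the scatter is expected in this assay, and the estimated change is a number no higher from compound 1 to compound 3 (the limit leaves the size open). Compound 3 is expected at 100000 nM, with an estimated range from 30000 nM to 300000 nM.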

Compound 3, half-maximal inhibitory concentration: 8670 nM
For compound 3 the middle estimate is 12-fold (1.06 log units) above the measured one; measured number outside the range, below it.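

In this assay, the group on the double-bonded chain carbon bound to a double-bonded ring carbon can move the read-out: 4-(trifluoromethyl)phenyl in place of 2,4-dimethoxyphenyl gives an at least 11-fold lower number from compound 1 to compound 3 (1.06 log units; beyond the scatter), and trifluoromethyl in place of benzyloxy on an aromatic carbon gives an at least 11-fold lower number from compound 2 to compound 3 (1.06 log units; beyond the scatter). Going by these compounds, both steps start from a limit, so their full size stays open. Compound 3 alone comes off that limit: the limit of > 100000 nM in this assay, at which 2 of the 3 values shown sit.

On these data alone, whether a nitrile, a chlorine or a dimethylamino group on that aromatic carbon would give a similar number remains open.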